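The source may report more compounds than this note shows. Statements on the series, on what has been measured and on what is new or still open speak of the compounds shown alone.

Measured in a functional assay on cells (leukaemia cell line, Homo sapiens) for inhibition, read by sulforhodamine B assay, with a stated time of 48 h; a lower number here means a stronger inhibitor of growth, a higher number a weaker inhibitor of growth:
Compound 1 `O=S(=O)(Nc1ccc(Cl)cc1Cl)c1ccc(-c2cnc(C3CC3)o2)cc1`: 481 nM
Compound 2 `O=S(=O)(Nc1ccc(Br)c(Cl)c1)c1ccc(-c2cnc(C3CC3)o2)cc1`: 491 nM
Compound 3 `O=S(=O)(Nc1cc(Cl)ccc1Cl)c1ccc(-c2cnc(C3CC3)o2)cc1`: 1020 nM

Of these three, compound 3 has the highest number and is the weakest inhibitor of growth. Compound 4 `Cc1ccc(Cl)c(NS(=O)(=O)c2ccc(-c3cnc(C4CC4)o3)cc2)c1` has not yet been measured. It has methyl in place of chloro on an aromatic carbon, turning 2,5-dichlorophenyl into 2-chloro-5-methylphenyl: methyl in place of chloro on an aromatic carbon. Among the measured compounds shown here, no measured step makes this exact swap. The nearest evidence comes from other changes on the phenyl group on the sulfonamide nitrogen: a 2.1-fold higher number from compound 1 to compound 3 (0.33 log units; beyond the scatter), a 2.1-fold higher number from compound 2 to compound 3 (0.32 log units; beyond the scatter) and a 1.0-fold higher number from compound 1 to compound 2 (0.01 log units; within the scatter). A modest step could therefore occur in either direction in this assay, but none beyond the scatter is most likely. The expected step is a 1.0-fold lower number from compound 3 to compound 4 (0.01 log units; within the scatter). For compound 4 the estimated value is 1000 nM, with an expected range of 500 nM to 2000 nM.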

Compound 4, concentration for 50% growth inhibition: 48.8 nM
For compound 4 the middle estimate is 20-fold (1.31 log units) above the measured one; measured number outside the range, below it.
By their numbers in this assay, from the lowest: compound 4; then compounds 1 and 2 (each within the scatter of the next); then compound 3.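

In this assay, among the compounds shown here, replacing chloro with methyl, at the place para to a chloro group, gives a 21-fold lower number from compound 3 to compound 4 (1.32 log units; beyond the scatter), a far larger step than any among the earlier compounds, so this position responds strongly to this one-atom change. The 2-chloro-5-methylphenyl group also outdoes both other substitution patterns, with a 10-fold lower number from compound 2 to compound 4 (1.00 log units; beyond the scatter) and a 9.9-fold lower number from compound 1 to compound 4 (0.99 log units; beyond the scatter), and gives the strongest inhibitor of growth of the four. No measurement shown explains this gain.

Going by these compounds, whether the gain is specific to methyl stays open, since ethyl, methoxy or an amine at this place would test it. Also open, on these data alone, is whether methyl keeps this effect if the remaining chloro is replaced by bromo.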